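Fluoro for trifluoromethyl on the carboxy compound

This account rests on a few compounds, and the source may have more. Where it says the series, first, only, none or still open, it means among the compounds named here.

Compound 3 `O=C(O)c1cnc2c(C(F)(F)F)cccc2c1` carries carboxy on the shared core, and in a functional assay on the whole organism (strain Sprague-Dawley) for inhibition, with Rattus norvegicus as the target (on this read-out higher numbers stand for an effect only at larger amounts of compound and lower numbers for an effect already at smaller amounts), compound 3 gives 50 mg/kg. Among the two numbers shown this is the highest; the nearest is compound 2 `CCCCc1ccc2ncc(-c3nn[nH]n3)cc2c1`, which in this assay gives 5 mg/kg, a gap recorded as beyond the scatter. Compound 1 `FC(F)(F)c1cccc2cc(-c3nn[nH]n3)cnc12` shows in this assay only a limit of the assay, < 25 mg/kg. Among the measured compounds shown here, the single one-place step measured, an at least 2.0-fold higher number from compound 1 to compound 3 (0.30 log units; that floor lies within the scatter), rests on that limit of < 25 mg/kg in this assay, at which 1 of the 3 values shown sits, and concerns the exchange of the tetrazolyl group for carboxy, not the substituent on the six-membered aromatic ring of carbon only.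

Compound 4 `O=C(O)c1cnc2c(F)cccc2c1` differs from compound 3 in one place: fluoro in place of trifluoromethyl on an aromatic carbon. For the measured compounds named here, no measured step touches this change; the step from compound 1 to compound 3 and the gap between compound 2 and compound 3 involve other parts of the molecule, so they give no direction for it. The expectation is therefore no step beyond the scatter, no change at the digits printed from compound 3 to compound 4 (within the scatter), with the range kept wide for want of a comparable step. Compound 4 is estimated in this assay at 50 mg/kg, between 20 mg/kg and 125 mg/kg.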

Compound 4, minimum effective dose: > 25 mg/kg
Compound 4 was reported as a limit (the forecaster's own chance of this, stated with the estimate: 15%); the middle value does not contradict the limit.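

In this assay compound 4 gives > 25 mg/kg, which is a limit of the assay. Among the compounds shown here, no step from compound 3 to compound 4 can be read from it. The compounds shown leave open whether fluoro in place of trifluoromethyl on an aromatic carbon changes the minimum effective dose of the carboxy compounds beyond the scatter.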